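Methyl on the anilino ring: compound 4 from compound 2

This account rests on a few compounds, and the source may have more. Where it says the series, first, only, none or still open, it means among the compounds named here.

All three measured compounds were tested in a functional assay on NCI-H1975 cells (Homo sapiens) for inhibition, read by MTT assay, with a stated time of 72 h; on this read-out lower numbers stand for stronger inhibition and higher numbers for weaker inhibition:
compound 1 `O=C(CSc1nc(Nc2ccccc2)c2ccccc2n1)Nc1cccc(F)c1` gives 6790 nM
compound 2 `C=CC(=O)Nc1cccc(NC(=O)CSc2nc(Nc3ccccc3)c3ccccc3n2)c1` gives 8120 nM
compound 3 `O=C(CSc1nc(Nc2ccccc2)c2ccccc2n1)Nc1ccc(F)c(Cl)c1` gives 9390 nM

Compound 2 holds the second highest of the three numbers. The nearest is compound 3, reached by a 1.2-fold higher number from compound 2 to compound 3 (0.06 log units; within the scatter); the furthest is compound 1, from which compound 2 is reached by a 1.2-fold higher number from compound 1 to compound 2 (0.08 log units; within the scatter). Compound 3 differs from compound 1 by a 1.4-fold higher number from compound 1 to compound 3 (0.14 log units; within the scatter). Each of these steps alters only the aryl group on the amide-type nitrogen, and all three lie within the scatter.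

Compound 4 `C=CC(=O)Nc1cccc(NC(=O)CSc2nc(Nc3cccc(C)c3)c3ccccc3n2)c1` differs from compound 2 by methyl in place of hydrogen on an aromatic carbon. Among the compounds with values here, no measured step touches the anilino part of the shared core, so none bears directly on this change; the only guidance is that every measured variation of an aromatic substituent stayed within the scatter. The expected step is therefore a 1.0-fold lower number from compound 2 to compound 4 (0.01 log units; within the scatter), no movement beyond the scatter. In this assay compound 4 is estimated at 8000 nM, within a range of 4000 nM to 16000 nM.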

Compound 4, half-maximal inhibitory concentration: 12100 nM
Beside the measured number, compound 4's estimate is 1.5-fold (0.18 log units) below it, within the range that was stated.
By their numbers in this assay, from the lowest: compounds 1, 2, 3 and 4 (each within the scatter of the next).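

The anilino part of the shared core now has a measured change: phenyl to 3-methylphenyl reads in this assay as a 1.5-fold higher number from compound 2 to compound 4 (0.17 log units; within the scatter). A methyl on this aromatic carbon, meta to a large group, is therefore accommodated without separating compound 4 from compound 2, so this ring position behaves like the aryl group on the amide-type nitrogen, where the steps also stayed within the scatter. No supporting measurement is available to account for the size of this step.

From the compounds shown here alone, it remains open whether a larger or different group at this position, such as methoxy, chloro, an amine or a carboxylic acid, would move the number beyond the scatter. Also open, going by these compounds, is whether the same methyl would read alike on the 3-fluorophenyl amide of compound 1, which lacks the (vinylcarbonyl)amino group.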